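Adding a methoxy group to the benzoate ester of compound 1

The compounds below may be only part of what the source reports. "The series", "measured", "known", "first", "only" and "open" are said of these compounds alone.

Measured so far:
compound 1 `CC1=CC[C@H](C(C)C)c2cc(C)c(OC(=O)c3ccccc3)cc21`: 22.5%
compound 2 `CC1=CC[C@H](C(C)C)c2cc(C)c(OC(=O)c3cccc(C(F)(F)F)c3)cc21`: 25.4%
compound 3 `COc1ccc(C(=O)Oc2cc3c(C)ccc(C(C)C)c3cc2C)cc1`: 10.4%

These compounds were tested in a functional assay on PC-3 cells (Homo sapiens) for antiproliferative activity, read by sulforhodamine B assay, with a stated time of 48 h, tested at 50 uM; on this read-out lower numbers stand for less inhibition and higher numbers for more inhibition at the one concentration tested (going by the name of the read-out). Compound 1 stands second highest of the three, close to compound 2 and well above compound 3. Among the measured compounds shown here, the one measured step on this core, a number 2.9 percentage points higher from compound 1 to compound 2 (within the scatter), lies within the scatter. Compound 4 `COc1ccc(C(=O)Oc2cc3c(cc2C)[C@@H](C(C)C)CC=C3C)cc1` carries the change (methoxy in place of hydrogen on an aromatic carbon). For the measured compounds named here, no measured step covers a methoxy group entering on this core; compound 3 also bears a methoxy group but on a different core, so its value cannot be converted into a step. The expectation is therefore a step of about a number 2.5 percentage points lower from compound 1 to compound 4 (within the scatter), no clear direction beyond the scatter. Compound 4 is estimated to give 20%, within 5% to 35%.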

Compound 4, a percentage reported as inhibition, at one concentration (the size of the read-out at that concentration, not a potency): 60.6%
The estimate for compound 4 lay 40.6 percentage points below the measured number; the whole stated range lies below it.
By their numbers in this assay, from the lowest: compound 3; then compounds 1 and 2 (each within the scatter of the next); then compound 4.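

In this assay, methoxy in place of hydrogen on the benzoate's aromatic ring, para to a large group, gives a large gain: a number 38.1 percentage points higher from compound 1 to compound 4 (beyond the scatter). Among the compounds shown here, the earlier step on this core, a number 2.9 percentage points higher from compound 1 to compound 2 (within the scatter), showed no change beyond the scatter, so this result is the first sign that a substituent on this ring can shift the number. No supporting measurement bears on what lies behind the gain.

On these data alone, it remains open whether a hydroxyl group, an amine or a longer ether chain at this place would give a similar gain. Also open, as far as these compounds go, is whether methoxy would do so elsewhere on the ring.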